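Trading the Amide Carbonyl for a Sulfonyl Group

A few compounds are considered here, and "the series" means these few. Any claim that something is new, unique, unknown or untested is made for them only; others in the source may bear on it.

Compound 1 `O=C(Nc1cccc(/C=C/C(=O)c2nc3ccccc3[nH]2)c1)c1ccc(Cl)cc1` gives 2270 nM in a functional assay on HCT-116 cells (Homo sapiens) for antiproliferative activity, read by MTT assay, with a stated time of 48 h; on this read-out higher numbers stand for weaker inhibition and lower numbers for stronger inhibition.
Compound 2 `Cc1cc(C)cc(C(=O)Nc2cccc(/C=C/C(=O)c3nc4ccccc4[nH]3)c2)c1` gives 1550 nM in this assay.

Both measured compounds share the same core and differ only in the aryl group on the carbonyl carbon. Among the compounds with values here, the single measured step, a 1.5-fold lower number from compound 1 to compound 2 (0.17 log units; within the scatter), lies within the scatter, so compound 2 and compound 1 cannot be told apart on these numbers; compound 2 simply shows the lower of the two values.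

Compound 3 `Cc1cccc(S(=O)(=O)Nc2cccc(/C=C/C(=O)c3nc4ccccc4[nH]3)c2)c1` is the next compound. It differs from compound 2 by (3-methylphenyl)sulfonyl in place of (3,5-dimethylphenyl)carbonyl on a nitrogen on an aromatic ring. Within the data shown here, the only step seen so far swapped one aryl group for another while keeping the carbonyl, and it produced no change beyond the scatter. Among the measured compounds shown here, the change to compound 3 touches the linking group itself, which no measured pair covers, so the earlier step bears on it only loosely. The expectation is a step of no clear direction, a 1.3-fold higher number from compound 2 to compound 3 (0.11 log units; within the scatter), with wide uncertainty. Compound 3 is therefore estimated at 2000 nM in this assay, expected within the range 600 nM to 7000 nM.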

Compound 3, half-maximal inhibitory concentration: 597 nM
Compound 3: middle estimate off by 3.4-fold (0.53 log units), on the high side, and the stated range ends above it.
By their numbers in this assay, from the lowest: compound 3; then compounds 2 and 1 (each within the scatter of the next).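

Within the data shown here, on the nitrogen on the aromatic ring, the sulfonyl-linked aryl group gives the first steps in this short series that stand beyond the scatter: a 2.6-fold lower number from compound 2 to compound 3 (0.41 log units; beyond the scatter) and a 3.8-fold lower number from compound 1 to compound 3 (0.58 log units; beyond the scatter) are both modest, and a lower number in this assay means stronger inhibition. The two carbonyl compounds could not be told apart, with a 1.5-fold lower number from compound 1 to compound 2 (0.17 log units; within the scatter), whereas compound 3, with its sulfonyl link, is separated from both, so this position does respond to the change of group made here. Nothing available here explains why the number falls.

Each of these steps changes the link and the aryl ring together, as (3-methylphenyl)sulfonyl differs from (3,5-dimethylphenyl)carbonyl and from (4-chlorophenyl)carbonyl in both respects, so the share of the sulfonyl alone cannot be separated from that of the ring. As far as these compounds go, it also remains open whether the lower number would hold with a methylsulfonyl group, which carries no aryl ring at all, or with a urea link in this place on the shared core.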